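A few compounds are considered here, and "the series" means these few. Any claim that something is new, unique, unknown or untested is made for them only; others in the source may bear on it.

Values so far in a physicochemical assay for lipophilicity; a lower number here means a more polar compound, a higher number a more lipophilic compound:
- Compound 1 `CCOC(=O)C1=C(C)NC(=S)NC1c1cn(C(=O)CNc2ccccc2Cl)c2ccccc12` gives 3.44
- Compound 2 `CCOC(=O)C1=C(C)NC(=S)NC1c1cn(C(=O)CNc2ccc([N+](=O)[O-])cc2C)c2ccccc12` gives 3.34

Within the data shown here, with only two numbers to compare, compound 2 at 3.34 cannot be told apart from compound 1 at 3.44. Among the measured compounds shown here, the one measured step is a number 0.10 log units lower from compound 1 to compound 2 (within the scatter). That step bears on the next question only loosely. It replaces a whole 2-chlorophenyl with 2-methyl-4-nitrophenyl, so it does not show what the methyl alone contributes.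

The next compound, compound 3 `CCOC(=O)C1=C(C)NC(=S)NC1c1cn(C(=O)CNc2ccc([N+](=O)[O-])cc2)c2ccccc12`, has not yet been measured. Its difference from compound 2 is hydrogen in place of methyl on an aromatic carbon, which is hydrogen in place of methyl on an aromatic carbon, turning 2-methyl-4-nitrophenyl into 4-nitrophenyl. The rest of the molecule stays the same.

For the measured compounds named here, with no measured step isolating this change, the expectation rests on the structural change itself and starts from compound 2 at 3.34. The expected result is a number 0.34 log units lower from compound 2 to compound 3 (beyond the scatter), a modest move to a lower number. For compound 3 the estimated value is 3, with an expected range from 2.65 to 3.3.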

Compound 3, partition coefficient: 2.88
For compound 3 the middle estimate is 0.12 log units above the measured one, and the stated range covers the measured number.
By their numbers in this assay, from the lowest: compound 3; then compounds 2 and 1 (each within the scatter of the next).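

Taken alone, the methyl on the aromatic carbon ortho to a large group and meta to the nitro group makes a measurable difference in this assay: a number 0.46 log units lower from compound 2 to compound 3 (beyond the scatter) is the first step to isolate that single group. The earlier comparison, a number 0.10 log units lower from compound 1 to compound 2 (within the scatter), could not show this, since it exchanged a whole 2-chlorophenyl for 2-methyl-4-nitrophenyl. Without the methyl, the exchange of the ring substituents becomes readable, with a number 0.56 log units lower from compound 1 to compound 3 (beyond the scatter), so the closeness of compound 1 and compound 2 depends on that methyl being present. Nothing measured here gives a reason for these shifts.

On these data alone, only hydrogen and methyl have been compared on this aromatic carbon, so it remains open how an ethyl group, a methoxy group or a chlorine atom there would compare with them. As far as these compounds go, it is equally open whether the same methyl-to-hydrogen change would give a step of similar size on a ring carrying an amine or a carboxylic acid in place of the nitro group.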